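Swapping a phenol for a fluorophenyl on the thioether arm

A few compounds are considered here, and "the series" means these few. Any claim that something is new, unique, unknown or untested is made for them only; others in the source may bear on it.

Compound 1 `Cc1c(O)nc(SCc2ccc(O)cc2)nc1Cc1c(Cl)cccc1Cl`: 41000 nM
Compound 2 `Cc1c(Cc2c(F)cccc2F)nc(SCc2ccc([N+](=O)[O-])cc2)[nH]c1=O`: > 62000 nM
Compound 3 `COc1ccc(CS(=O)(=O)c2nc(O)c(C)c(Cc3c(Cl)cccc3Cl)n2)cc1`: 2800 nM

Of the compounds shown here, three sharing a core have been tested in a functional assay on MT4 cells (Homo sapiens) for cytotoxicity, read by MTT assay; a higher number here means that more compound is tolerated, a lower number that less compound is tolerated. Compound 1 gives 41000 nM, the higher of the two numbers recorded. Compound 3 gives 2800 nM in this assay, a gap to compound 1 that lies beyond the scatter. Compound 2 gives > 62000 nM, which is a limit of the assay rather than a number; that value is the limit of > 62000 nM in this assay, at which 1 of the 3 values shown sits.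

The next compound, compound 4 `Cc1c(O)nc(SCc2cccc(F)c2)nc1Cc1c(Cl)cccc1Cl`, has not yet been measured in this assay. It departs from compound 1 in one place: 3-fluorophenyl in place of 4-hydroxyphenyl on a saturated chain carbon bound to a sulfur. The 4-hydroxyphenyl leaves and a 3-fluorophenyl enters, on the saturated chain carbon bound to a sulfur.

No measured step between two of these compounds changes only this position, so the size of the step can only be guessed. Compound 4 is expected to stay near compound 1, with a step of a 1.2-fold lower number from compound 1 to compound 4 (0.07 log units; within the scatter) that lies within the scatter or just beyond it. In this assay compound 4 is therefore estimated at 35000 nM, with a range from 9000 nM to 100000 nM, and there is a fair chance that only a limit is reported.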

Compound 4, half-maximal cytotoxic concentration: > 61000 nM
Compound 4: only a limit was reported; the forecaster's own chance of this, stated with the estimate: 30%; middle value at least 1.7-fold (0.24 log units) from the limit.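

Setting 3-fluorophenyl in place of 4-hydroxyphenyl on the saturated chain carbon bound to a sulfur gives the first reading at this position in this assay, with an at least 1.4-fold higher number from compound 1 to compound 4 (0.17 log units; that floor lies within the scatter). Compound 4 reaches only a limit of the assay: the limit of > 61000 nM in this assay, at which 1 of the 4 values shown sits. The change therefore removes the hydrogen-bond donor and acceptor counted for the 4-hydroxyphenyl without any sign of a lower number, although the floor of the step alone does not separate compound 4 from compound 1.

The compounds shown leave open how far compound 4 really lies from compound 1, and whether the step belongs to the loss of the hydroxyl or to the arrival of the fluorine, since both change together in this single swap. They also leave open how the number would respond to an amine or a carboxylic acid on this phenyl ring, or to a longer chain in place of the single saturated chain carbon bound to the sulfur.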